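The source may report more compounds than this note shows. Statements on the series, on what has been measured and on what is new or still open speak of the compounds shown alone.

Working notes on the series. In an ADME assay on Vero cells (Chlorocebus sabaeus) for antiproliferative activity, read by MTT assay, with a stated time of 72 h (a lower number here means a stronger inhibitor, a higher number a weaker inhibitor), compound 1 (`CN(c1ccccc1)S(=O)(=O)C1CC2OC1C(c1ccc(NC(=O)CCCCCCC(=O)O)cc1)=C2c1ccc(O)cc1`) reads > 100000 nM as a limit of the assay. Compound 2 (`CN(c1ccccc1Cl)S(=O)(=O)C1CC2OC1C(c1ccc(NC(=O)CCCCCCC(=O)O)cc1)=C2c1ccc(O)cc1`) reads > 100000 nM as a limit of the assay. Compound 3 (`CN(c1cccc2ccccc12)S(=O)(=O)C1CC2OC1C(c1ccc(NC(=O)CCCCCCC(=O)O)cc1)=C2c1ccc(O)cc1`) reads > 100000 nM and so stands only at a limit, with no number. For the measured compounds named here, the series so far shows the limit of > 100000 nM in this assay, at which 3 of the 3 values shown sit, and nothing more.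

The next change leads to compound 4 (`CCN(c1ccc(C)cc1)S(=O)(=O)C1CC2OC1C(c1ccc(NC(=O)CCCCCCC(=O)O)cc1)=C2c1ccc(O)cc1`), with ethyl(4-methylphenyl)amino in place of methyl(naphthalen-1-yl)amino on a sulfonyl sulfur. Bearing on it are a step that the two limits leave unreadable from compound 1 to compound 3 and a step that the two limits leave unreadable from compound 2 to compound 3 and also a step that the two limits leave unreadable from compound 1 to compound 2 with no size to read from any of them.

No step beyond the scatter is expected in this assay because of the limit of > 100000 nM in this assay, at which 3 of the 3 values shown sit, and no direction can be given. The expected step is a number no higher from compound 3 to compound 4 (the limit leaves the size open) as far as an estimate can state it. Compound 4 is estimated at 100000 nM within an expected range of 50000 nM to 200000 nM and will most likely be reported only as a limit.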

Compound 4, half-maximal inhibitory concentration: > 100000 nM
Compound 4: no number, only a limit; the forecaster's own chance of this, stated with the estimate: 90%; the middle value sits exactly at the limit.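

In this assay compound 4 reads > 100000 nM, a limit of the assay and not a number, so its steps from compound 1, compound 2 and compound 3 cannot be read. The series stands at a single point: the limit of > 100000 nM in this assay, at which 4 of the 4 values shown sit.

The compounds shown leave open whether any group on the sulfonyl sulfur changes this read-out at all.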